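This account rests on a few compounds, and the source may have more. Where it says the series, first, only, none or still open, it means among the compounds named here.

Of the compounds shown here, three have so far been tested in an assay on HEK-293T cells for inhibition of diacylglycerol lipase-alpha (Homo sapiens), read by colorimetric assay; a higher number here means a weaker inhibitor, a lower number a stronger inhibitor. Compound 1 `O=C(CCCCCc1ccccc1)c1nc2ncccc2s1` gives > 10000 nM, which is a limit rather than a number. Compound 2 `O=C(CCCCCCc1ccccc1)c1ncc(-c2cccs2)s1` likewise gives > 10000 nM, again a limit and not a number. Going by the values given here, compound 3 `O=C(CCCCCCc1ccccc1)c1nc(C(=O)C(F)(F)F)co1` is the only one with a measured value: in this assay compound 3 gives 123 nM. Among the compounds with values here, compound 3 therefore stands alone as the single number in the set. The other two values sit at the limit of > 10000 nM in this assay, at which 2 of the 3 values shown sit.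

The next compound, compound 4 `COc1coc(C(=O)CCCCCCc2ccccc2)n1`, keeps the phenyl-bearing chain and the shared core of compound 3 but differs at one place: methoxy in place of (trifluoromethyl)carbonyl on an aromatic carbon. Within the data shown here, no step between two measured compounds is available to show how much such a swap shifts the read-out, so the expectation rests on the overall picture alone. Among the measured compounds shown here, compound 3 carries the one measured number, while compound 1 and compound 2 both lie at the limit of > 10000 nM in this assay, at which 2 of the 3 values shown sit; removing the (trifluoromethyl)carbonyl of compound 3 is expected to move compound 4 back toward that limit. The step from compound 3 to compound 4 is thus estimated as a 98-fold higher number from compound 3 to compound 4 (1.99 log units; beyond the scatter), a large weakening well beyond the usual scatter. For compound 4 the expected value in this assay is 12000 nM, within a range of 2000 nM to 60000 nM, with a real chance that only a limit is reported.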

Compound 4, half-maximal inhibitory concentration: > 10000 nM
Compound 4: only a limit was reported (the forecaster's own chance of this, stated with the estimate: 65%); the middle value does not contradict the limit.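

Going by these compounds alone, with methoxy in place of (trifluoromethyl)carbonyl on the aromatic carbon next to the ring nitrogen, this assay shows an at least 81-fold higher number from compound 3 to compound 4 (1.91 log units; beyond the scatter), the first step in the set that isolates a single place. The phenyl-bearing chain and the shared core are the same in both compounds, so they do not secure a measured inhibition on their own, and the group at this one position decides between a real number and no measurable value. Compound 4 gives only a limit, so the true size of the loss stays unknown, and the compound joins the group at that limit: the limit of > 10000 nM in this assay, at which 3 of the 4 values shown sit.

The compounds shown leave open which part of the (trifluoromethyl)carbonyl matters, the carbonyl or the trifluoromethyl, and an acetyl group at this position, keeping the carbonyl without the fluorines, would separate the two. Within the data shown here, they also leave open whether a different group there, such as a nitrile or an ester, could bring back a measured value, and whether that value would match or beat the one for compound 3.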